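Uridine triphosphate analogues: aryl change on the oxime chain

The source may hold more compounds than are shown below. What is called first, only, known or untested is meant among the compounds shown, and "the series" means these compounds.

Measured so far:
compound 1 `O=c1[nH]/c(=N\OCCCCc2ccccc2)ccn1[C@@H]1O[C@H](COP(=O)(O)OP(=O)(O)OP(=O)(O)O)[C@@H](O)[C@H]1O`: 214 nM
compound 2 `O=c1[nH]/c(=N\OCCOc2ccccc2)ccn1[C@@H]1O[C@H](COP(=O)(O)OP(=O)(O)OP(=O)(O)O)[C@@H](O)[C@H]1O`: 3400 nM
compound 3 `O=c1[nH]/c(=N\OCCCc2ccc(F)cc2)ccn1[C@@H]1O[C@H](COP(=O)(O)OP(=O)(O)OP(=O)(O)O)[C@@H](O)[C@H]1O`: 547 nM

In a functional assay on 1321-N1 cells for agonist activity at P2Y purinoceptor 2 (Homo sapiens), read by scintillation counting and inositol phosphate accumulation (a higher number here means that more compound is needed for the effect, a lower number that less compound is needed), compound 3 stands second of the three numbers. The two steps that reach it are a 2.6-fold higher number from compound 1 to compound 3 (0.41 log units; beyond the scatter) and a 6.2-fold lower number from compound 2 to compound 3 (0.79 log units; beyond the scatter), and a 16-fold higher number from compound 1 to compound 2 (1.20 log units; beyond the scatter) frames the spread of the set.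

Compound 4 `O=c1[nH]/c(=N\OCCCc2cccc([N+](=O)[O-])c2)ccn1[C@@H]1O[C@H](COP(=O)(O)OP(=O)(O)OP(=O)(O)O)[C@@H](O)[C@H]1O` differs from compound 3 by 3-nitrophenyl in place of 4-fluorophenyl on a saturated chain carbon, three bonds along the chain from an oxygen. Among the measured compounds shown here, no measured step alters a substituent on the aryl ring itself; the steps at hand move the ring along the chain or swap ring and linker, all modest to large. Only a modest shift in this assay is therefore expected, with the direction uncertain, leaning towards a slightly higher number for compound 4. Compound 4 is estimated at 650 nM, between 250 nM and 1700 nM, a step of a 1.2-fold higher number from compound 3 to compound 4 (0.07 log units; within the scatter).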

Compound 4, half-maximal effective concentration: 457 nM
Beside the measured number, compound 4's estimate is 1.4-fold (0.15 log units) above it, within the range that was stated.
By their numbers in this assay, from the lowest: compound 1; then compounds 4 and 3 (each within the scatter of the next); then compound 2.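

In this assay, a change on the aryl ring itself, 3-nitrophenyl in place of 4-fluorophenyl on a saturated chain carbon, gives a 1.2-fold lower number from compound 3 to compound 4 (0.08 log units; within the scatter), so these two aryl groups cannot be told apart here. The other steps, a 7.4-fold lower number from compound 2 to compound 4 (0.87 log units; beyond the scatter) and a 2.1-fold higher number from compound 1 to compound 4 (0.33 log units; beyond the scatter), keep compound 4 in the same relation to compound 1 and compound 2 that compound 3 already showed. No measurement at hand accounts for these numbers.

As far as these compounds go, whether an amine or a carboxylic acid on the aryl ring would be tolerated as well stays open, as does whether ring substituents behave alike on the chain of compound 1.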